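A few compounds are considered here, and "the series" means these few. Any claim that something is new, unique, unknown or untested is made for them only; others in the source may bear on it.

Compound 2 `COc1ccc(NC(=O)O/N=C(\C)c2cccc(-c3ccccc3)c2)cc1` and compound 1 `C/C(=N\OC(=O)Nc1ccc(F)cc1)c1cccc(-c2ccccc2)c1` share one core, a carbamate whose nitrogen carries an aromatic ring. In an assay for inhibition of Fatty-acid amide hydrolase 1 (Mus musculus), read by scintillation counting (on this read-out lower numbers stand for stronger inhibition and higher numbers for weaker inhibition), compound 1 gives 17 nM, and compound 2 gives 28 nM. The only measured step, a 1.6-fold higher number from compound 1 to compound 2 (0.22 log units; within the scatter), leaves the two within the scatter of each other, so on the numbers shown compound 2 stands with the higher of the two figures, and nothing in that difference can be read as a real change.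

Compound 3 `C/C(=N\OC(=O)Nc1ccc2sccc2c1)c1cccc(-c2ccccc2)c1` keeps this core and changes the group on the carbamate nitrogen: 1-benzothiophen-5-yl in place of 4-methoxyphenyl on an amide-type nitrogen. Among the compounds with values here, no measured step exchanges a whole aromatic ring in this position; the one step that bears on it, a 1.6-fold higher number from compound 1 to compound 2 (0.22 log units; within the scatter), only swaps a substituent on that ring and stayed within the scatter. With so little to go on, the expected step of a 1.1-fold lower number from compound 2 to compound 3 (0.05 log units; within the scatter) is modest and of uncertain direction, and the expectation is held loosely. Compound 3 is therefore estimated at 25 nM in this assay, within a range of 8 nM to 80 nM.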

Compound 3, half-maximal inhibitory concentration: 232 nM
Compound 3: middle estimate off by 9.3-fold (0.97 log units), on the low side; the whole stated range lies below it.
By their numbers in this assay, from the lowest: compounds 1 and 2 (each within the scatter of the next); then compound 3.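

In this assay, the group on the carbamate nitrogen proves able to shift the number well beyond the scatter, which the earlier swap of a substituent on the ring, a 1.6-fold higher number from compound 1 to compound 2 (0.22 log units; within the scatter), did not show. Exchanging the whole aromatic group gives an 8.3-fold higher number from compound 2 to compound 3 (0.92 log units; beyond the scatter) for 1-benzothiophen-5-yl in place of 4-methoxyphenyl, and a 14-fold higher number from compound 1 to compound 3 (1.14 log units; beyond the scatter) for 1-benzothiophen-5-yl in place of 4-fluorophenyl, so both steps into compound 3 run towards weaker inhibition and this position is not indifferent to the group it carries. Nothing available explains why the number rises on this exchange.

The compounds shown do not separate the sulfur of 1-benzothiophen-5-yl from its second aromatic ring, since compound 3 brings in both at once, and the single example cannot say which of the two goes with the higher number. Also open, on these data alone, is how this position would read with a group of quite another kind on the carbamate nitrogen, such as a butyl chain, or with an amine or a carboxylic acid on the phenyl ring in place of the fluoro or methoxy.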